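Phenyl in place of methylpyrazolyl: expected oral exposure

The compounds below may be only part of what the source reports. "The series", "measured", "known", "first", "only" and "open" are said of these compounds alone.

Three compounds have been measured in an ADME assay on the whole organism (Mus musculus) for pharmacokinetics, at a dose of 50 mg/kg by the oral route; on this read-out lower numbers stand for lower exposure and higher numbers for higher exposure at the dose given:
compound 1 `CC(C)(C)c1cc(S(C)(=O)=O)cc(S(=O)(=O)c2ccc(CN)s2)c1` gives 16000 nM;
compound 2 `CC(C)(C)Oc1cc(S(C)(=O)=O)cc(S(=O)(=O)c2ccc(CN)s2)c1` gives 6300 nM;
compound 3 `Cn1cc(-c2cc(S(=O)(=O)c3ccc(CN)s3)ccc2S(C)(=O)=O)cn1` gives 9600 nM.

Compound 3 stands second highest of the three numbers. Its nearest neighbour is compound 2 and its furthest is compound 1, yet both gaps lie within the scatter, so no order among the three can be read from this assay.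

Compound 4 `CS(=O)(=O)c1ccc(S(=O)(=O)c2ccc(CN)s2)cc1-c1ccccc1` differs from compound 3 in one place: phenyl in place of 1-methyl-1H-pyrazol-4-yl on an aromatic carbon. Within the data shown here, the only measured step, a 2.5-fold lower number from compound 1 to compound 2 (0.40 log units; beyond the scatter), concerns a different position and a different pair of groups, so it does not bear on this change. With nothing measured on the change itself, compound 3 is the anchor and no step beyond the scatter is expected: a 1.1-fold lower number from compound 3 to compound 4 (0.03 log units; within the scatter). Compound 4 is therefore expected to give 9000 nM, within 3500 nM to 23000 nM.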

Compound 4, maximal plasma concentration: 1600 nM
Compound 4: middle estimate off by 5.6-fold (0.75 log units), on the high side; measured number outside the range, below it.
By their numbers in this assay, from the lowest: compound 4; then compounds 2, 3 and 1 (each within the scatter of the next, the first and the last beyond it).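

At the aromatic carbon ortho to a methylsulfonyl group, the choice of ring matters in this assay: phenyl in place of 1-methyl-1H-pyrazol-4-yl gives a 6.0-fold lower number from compound 3 to compound 4 (0.78 log units; beyond the scatter). Both groups have 6 heavy atoms, so this position distinguishes between rings of equal heavy-atom count, one with 2 hydrogen-bond acceptors and one with none. No measurement shown accounts for this step.

From the compounds shown here alone, it remains open whether a single ring nitrogen, as in a pyridyl group, would give exposure nearer compound 3 or compound 4. Going by these compounds, it is equally open how a phenyl ring carrying an amine or a carboxylic acid would behave here.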